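The compounds below may be only part of what the source reports. "The series", "measured", "known", "first", "only" and "open" are said of these compounds alone.

Of the compounds shown here, two have been measured in an assay on isolated protein for displacement of a labelled ligand from Apoptosis regulator Bcl-2 (Homo sapiens), read by fluorescence polarization; on this read-out lower numbers stand for stronger inhibition and higher numbers for weaker inhibition. Compound 1, `CC1(C)CCN(c2ccc(C(=O)NS(=O)(=O)c3ccc(NC(C)(C)CSc4ccccc4)c([N+](=O)[O-])c3)cc2)CC1`, gives 67 nM in this assay. Compound 2, `CCCCCC1(OC)CCN(c2ccc(C(=O)NS(=O)(=O)c3ccc(N[C@H](CCN(C)C)CSc4ccccc4)c([N+](=O)[O-])c3)cc2)CC1`, gives 20 nM in this assay. Of the two numbers, compound 2 holds the lower one, and the gap up to compound 1 lies beyond the scatter of repeated measurements of this kind, so compound 2 stands as the stronger binder of the pair.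

Compound 3, `COC1(Cc2cccc(Cl)c2)CCN(c2ccc(C(=O)NS(=O)(=O)c3ccc(N[C@H](CCN(C)C)CSc4ccccc4)c([N+](=O)[O-])c3)cc2)CC1`, shares the core of compound 2 and differs from it in one place: 3-chlorophenyl in place of butyl on a saturated chain carbon bound to a saturated ring carbon. A four-carbon chain gives way to a chlorinated aromatic ring, so the group grows and changes its shape, while the counts of hydrogen-bond donors and acceptors and the net charge stay as they were. For the measured compounds named here, no measured pair shows this kind of change, so there is no step to lean on. Going by the values given here, with only the single number of compound 2 as a point of departure, the change from compound 2 to compound 3 is expected to move the result little, with no direction beyond the scatter, which is expressed as an expected step of a 1.1-fold lower number from compound 2 to compound 3 (0.05 log units; within the scatter) in this assay. Compound 3 is therefore estimated at 18 nM in this assay, with a range from 6 nM to 55 nM.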

Compound 3, inhibition constant: 1.8 nM
Beside the measured number, compound 3's estimate is 10-fold (1.00 log units) above it; the measured number lies below the stated range.
By their numbers in this assay, from the lowest: compound 3; then compound 2; then compound 1.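

This position, on a saturated chain carbon bound to a saturated ring carbon, proves highly sensitive in this assay: replacing butyl with 3-chlorophenyl gives an 11-fold lower number from compound 2 to compound 3 (1.05 log units; beyond the scatter), a large step well beyond the scatter. Both groups have the same counts of hydrogen-bond donors and acceptors and no net charge, so those counts do not distinguish them; the listed differences are the larger group, the six-membered aromatic ring and the chlorine. Nothing available here bears on why binding changes so much, or on which of these differences matters.

With the ring and the chlorine entering together, this single step cannot separate their contributions: a plain phenyl at the same place would isolate the chlorine, while a cyclohexyl would test whether the ring needs to be aromatic. Also open, from the compounds shown here alone, is whether a longer chain such as hexyl, or an amine or carboxylic acid on the ring, would keep, lose or extend the strong binding seen for compound 3.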